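Replacing a Methyl by Methoxy on the Amide Nitrogen

The source may report more compounds than this note shows. Statements on the series, on what has been measured and on what is new or still open speak of the compounds shown alone.

For the measured compounds named here, compound 1 `CCCC(=O)C1=Cc2ccc(OC)cc2OC1c1cc(OC)c(OC)c(OC)c1` carries a propyl group on its carbonyl carbon and is the only member of this set that gives a number in a functional assay for inhibition of nuclear factor NF-kappa-B complex (Homo sapiens) (on this read-out higher numbers stand for weaker inhibition and lower numbers for stronger inhibition), where compound 1 gives 11700 nM. Compound 2 `COc1ccc2c(c1)OC(c1cc(OC)c(OC)c(OC)c1)C(C(=O)O)=C2` has hydroxy in place of propyl on that carbonyl carbon. In this assay compound 2 reaches only the limit > 50000 nM. Compound 3 `COc1ccc2c(c1)OC(c1cc(OC)c(OC)c(OC)c1)C(C(=O)N(C)C)=C2` carries dimethylamino in that place. In this assay compound 3 likewise reaches only the limit > 50000 nM. Compound 3 thus stands at the weak end of what can be read, sharing the limit of > 50000 nM in this assay, at which 2 of the 3 values shown sit, with compound 2; the steps of an at least 4.2-fold higher number from compound 1 to compound 2 (0.63 log units; beyond the scatter) and an at least 4.2-fold higher number from compound 1 to compound 3 (0.63 log units; beyond the scatter) are open-ended, and a step that the two limits leave unreadable from compound 2 to compound 3 cannot be sized.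

Compound 4 `COc1ccc2c(c1)OC(c1cc(OC)c(OC)c(OC)c1)C(C(=O)N(C)OC)=C2` differs from compound 3 by one change: methoxy in place of methyl on an amide-type nitrogen. No measured step touches the amide-type nitrogen; an at least 4.2-fold higher number from compound 1 to compound 3 (0.63 log units; beyond the scatter) and a step that the two limits leave unreadable from compound 2 to compound 3 only show that both replacements of propyl push the number past the limit and give no reason to expect methoxy to pull it back. The expected step is therefore a number no higher from compound 3 to compound 4 (the limit leaves the size open). Compound 4 is expected to give about 50000 nM in this assay, within 20000 nM to 200000 nM, most likely again as a limit.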

Compound 4, half-maximal inhibitory concentration: 11700 nM
Beside the measured number, compound 4's estimate is 4.3-fold (0.63 log units) above it, and the stated range ends above it.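

On the amide-type nitrogen, methoxy in place of methyl brings the read-out back from the limit in this assay, giving an at least 4.2-fold lower number from compound 3 to compound 4 (0.63 log units; beyond the scatter), so a nitrogen group on this carbonyl carbon does not by itself cost the measurable number. For the compounds shown here, measured against hydroxy on the same carbonyl carbon, methoxy(methyl)amino gives an at least 4.2-fold lower number from compound 2 to compound 4 (0.63 log units; beyond the scatter), while measured against propyl it gives no change at the digits printed from compound 1 to compound 4 (within the scatter), which puts it level with the only other compound that yields a number. The first two steps stay open-ended, as compound 2 and compound 3 each remain a limit: the limit of > 50000 nM in this assay, at which 2 of the 4 values shown sit.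

The compounds shown do not tell whether ethoxy or hydroxy on the amide-type nitrogen would also give a number. They also leave open how a butyl chain in place of propyl on the carbonyl carbon would read.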